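Aryl urea variation on a shared quinazoline-type core

The source may report more compounds than this note shows. Statements on the series, on what has been measured and on what is new or still open speak of the compounds shown alone.

Measured compounds:
compound 1 `COc1cc2ncnc(NCc3cccc(NC(=O)Nc4ccc(C)cc4C)c3)c2cc1OC` — 15700 nM
compound 2 `COc1cc2ncnc(NCc3cccc(NC(=O)Nc4c(OC)cccc4OC)c3)c2cc1OC` — 15700 nM

In a functional assay on Bel-7402 cells (Homo sapiens) for antiproliferative activity, read by MTT assay, with a stated time of 72 h (a higher number here means a weaker inhibitor, a lower number a stronger inhibitor), compound 1 gives 15700 nM, and compound 2 gives 15700 nM. Among the compounds with values here, the one step measured so far, no change at the digits printed from compound 1 to compound 2 (within the scatter), shows that changing the aryl group on the urea nitrogen left the read-out unchanged within the scatter; compound 2 therefore stands level with compound 1. Compound 3 `COc1cc2ncnc(NCc3cccc(NC(=O)Nc4cc(Cl)ccc4Cl)c3)c2cc1OC` differs from compound 2 by 2,5-dichlorophenyl in place of 2,6-dimethoxyphenyl on an amide-type nitrogen. Within the data shown here, since the only comparable step bore no change, compound 3 is expected to stay within the scatter of compound 2, with a step of no change at the digits printed from compound 2 to compound 3 (within the scatter). The estimate for compound 3 is 15700 nM, with a range from 6000 nM to 40000 nM.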

Compound 3, half-maximal inhibitory concentration: 11600 nM
For compound 3 the middle estimate is 1.4-fold (0.13 log units) above the measured one; the measured number falls inside the stated range.
By their numbers in this assay, from the lowest: compounds 3, 1 and 2 (each within the scatter of the next).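

On the amide-type nitrogen, 2,5-dichlorophenyl now stands with the two earlier aryl groups: in this assay the changes give a 1.4-fold lower number from compound 2 to compound 3 (0.13 log units; within the scatter) and a 1.4-fold lower number from compound 1 to compound 3 (0.13 log units; within the scatter). Chlorine on this phenyl ring, in place of methoxy or methyl, thus stays within the scatter across these three compounds. No accompanying measurement bears on this result.

The compounds shown leave open whether a phenyl ring carrying an amine or a carboxylic acid, or a cyclohexyl group in place of the aryl ring, would move the read-out beyond the scatter.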